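Methyl in place of chloro: compound 1 to compound 4

A few compounds are considered here, and "the series" means these few. Any claim that something is new, unique, unknown or untested is made for them only; others in the source may bear on it.

Three compounds of the series have values in a functional assay on cells (leukaemia cell line, Homo sapiens) for inhibition, read by sulforhodamine B assay, with a stated time of 48 h; a lower number here means a stronger inhibitor of growth, a higher number a weaker inhibitor of growth. Compound 1 `O=S(=O)(Nc1ccc(Cl)c(Cl)c1)c1ccc(-c2cnc(C3CC3)o2)cc1` gives 62100 nM, compound 2 `O=S(=O)(Nc1ccccc1Cl)c1ccc(-c2cnc(C3CC3)o2)cc1` gives 49700 nM and compound 3 `O=S(=O)(Nc1ccc(F)c(Cl)c1)c1ccc(-c2cnc(C3CC3)o2)cc1` gives 73700 nM. Compound 1 therefore stands within the scatter of both other compounds, and the three values cannot be ranked.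

Compound 4 `Cc1cc(NS(=O)(=O)c2ccc(-c3cnc(C4CC4)o3)cc2)ccc1Cl` keeps the core of compound 1 and changes 3,4-dichlorophenyl to 4-chloro-3-methylphenyl. This places methyl in place of chloro on an aromatic carbon, ortho to a chloro group and meta to a large group: methyl in place of chloro on an aromatic carbon.

The closest measured change is also a single exchange on an aromatic carbon, fluoro in place of chloro, and it gives a 1.2-fold higher number from compound 1 to compound 3 (0.07 log units; within the scatter). Replacing the whole 3,4-dichlorophenyl group with 2-chlorophenyl gives a 1.2-fold lower number from compound 1 to compound 2 (0.10 log units; within the scatter), and the remaining pair gives a 1.5-fold higher number from compound 2 to compound 3 (0.17 log units; within the scatter). All three steps lie within the scatter. Among the measured compounds shown here, none of the measured compounds carries a methyl group, so the series offers no direct precedent for this exchange.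

On the evidence of these three small steps, no shift in either direction beyond the scatter is expected, and the estimated step is a 1.0-fold lower number from compound 1 to compound 4 (0.01 log units; within the scatter). For compound 4 the expected value is 60000 nM, with an estimated range of 35000 nM to 100000 nM.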

Compound 4, concentration for total growth inhibition: 33400 nM
The estimate for compound 4 lay 1.8-fold (0.25 log units) above the measured number, outside the stated range (below it).
By their numbers in this assay, from the lowest: compounds 4, 2, 1 and 3 (each within the scatter of the next, the first and the last beyond it).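

In this assay, the methyl exchange on this aromatic carbon, ortho to a chloro group, gives a 1.9-fold lower number from compound 1 to compound 4 (0.27 log units; within the scatter), so this first methyl group in the series stays within the scatter of the 3,4-dichlorophenyl compound. Against the other two compounds the picture is split: a 2.2-fold lower number from compound 3 to compound 4 (0.34 log units; beyond the scatter) is the only step so far to pass the scatter, and only modestly, while a 1.5-fold lower number from compound 2 to compound 4 (0.17 log units; within the scatter) remains inside it, so 4-chloro-3-methylphenyl separates from 3-chloro-4-fluorophenyl but not from 2-chlorophenyl. No measurement shown here bears on why the methyl compound sits where it does.

The step to compound 4 from compound 3 alters two substituents on the sulfonamide aryl ring, so it cannot be assigned to the methyl group or to the chloro group alone. From the compounds shown here alone, whether a methoxy group, an amine or a carboxylic acid in place of the chloro ortho to the remaining chloro group would move the number beyond the scatter of compound 1 also stays open.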